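This account rests on a few compounds, and the source may have more. Where it says the series, first, only, none or still open, it means among the compounds named here.

Notes on the series. The shared core carries a hydroxyphenyl group and varies in the side chain on the other ring. Compound 1 `O=c1c(-c2ccc(O)cc2)coc2cc(CC3OC(CO)C(O)C(O)C3O)ccc12` and compound 2 `O=c1c(-c2ccc(O)cc2)coc2cc(OCCC3OCCCO3)ccc12` have been run in a functional assay on mitochondria (Cricetulus griseus) for inhibition of Monoamine oxidase (Homo sapiens), tested at 0.3 uM; a lower number here means a weaker effect, a higher number a stronger effect of the compound at the concentration tested. In this assay compound 1 gives 0%, while compound 2 gives 41%. Compound 2 thus stands highest of the two numbers recorded; its nearest neighbour is compound 1, a number lower by a margin beyond the usual scatter.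

Compound 3 `O=C(O)CCCCCCOc1ccc2c(=O)c(-c3ccc(O)cc3)coc2c1` has not yet been measured. It differs from compound 2 in one place: a group of 7 heavy atoms (5 carbon, 2 oxygen; no ring) in place of a group of 6 heavy atoms (4 carbon, 2 oxygen; one six-membered non-aromatic ring with 2 hetero atoms), on a saturated chain carbon, two bonds along the chain from an oxygen on an aromatic ring. Within the data shown here, no measured pair in the set shares this change, so the size of the step from compound 2 to compound 3 in this assay cannot be read from existing data; a moderate fall, at the edge of or beyond the scatter, is expected rather than a rise. The expected step is a number 16 percentage points lower from compound 2 to compound 3 (beyond the scatter). Compound 3 is therefore estimated at 25% in this assay, within a range from 5% to 50%.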

Compound 3, a percentage reported as inhibition, at one concentration (the size of the read-out at that concentration, not a potency): 48.6%
Estimate against measurement, compound 3: 23.6 percentage points below; low and high end bracket the measured number.
By their numbers in this assay, from the lowest: compound 1; then compounds 2 and 3 (each within the scatter of the next).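

In this assay, replacing the group with the six-membered non-aromatic ring by 4-carboxybutyl, on a saturated chain carbon, two bonds along the chain from an oxygen on an aromatic ring, gives a number 7.6 percentage points higher from compound 2 to compound 3 (within the scatter). Among these compounds, this is the first direct comparison at this position, and it shows that the read-out does not depend on keeping that ring: an open chain with no ring and with a hydrogen-bond donor, which the leaving group lacks, gives a result that cannot be told apart from it. No measurement available here accounts for this similarity.

A single pair at one concentration leaves open whether compound 2 and compound 3 would also match in potency, since a percentage from this assay does not give one. Going by these compounds, it also remains unknown whether the end of the 4-carboxybutyl group matters at all, which a primary amine or a methyl ester in its place could test, and how a shorter or longer chain carrying the same end group would read out.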